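A Hydroxyphenyl Swap Carried onto a Second Core

The source may hold more compounds than are shown below. What is called first, only, known or untested is meant among the compounds shown, and "the series" means these compounds.

Compound 2 `Cc1ccc(-c2cc(/C=C/c3ccc(C(=O)NO)cc3)ccn2)c(F)c1` gives 15 nM in an assay on isolated protein for inhibition of protein deacetylase HDAC6 (Homo sapiens), read by fluorescence, with a stated time of 15 min; a lower number here means a stronger inhibitor, a higher number a weaker inhibitor. Compound 1 `O=C(NO)c1ccc(/C=C/c2ccnc(-c3ccccc3O)c2)cc1` differs from it in one place, (2-hydroxyphenyl in place of 2-fluoro-4-methylphenyl on an aromatic carbon), and in this assay compound 1 gives 47 nM, a step of a 3.1-fold higher number from compound 2 to compound 1 (0.50 log units; beyond the scatter). Compound 3 `Cc1ccc(-c2cncc(/C=C/c3ccc(C(=O)NO)cc3)c2)c(F)c1` has the same atoms as compound 2 joined differently; how the two cores differ is not broken down here. In this assay compound 3 gives 150 nM. Compound 4 `O=C(NO)c1ccc(/C=C/c2cncc(-c3ccccc3O)c2)cc1` carries the same kind of change on the core of compound 3, (2-hydroxyphenyl in place of 2-fluoro-4-methylphenyl on an aromatic carbon), though the surroundings differ: in compound 1 the entering group sits next to the ring nitrogen, in compound 4 two atoms from the ring nitrogen. The author expects a step of a 2.7-fold higher number from compound 3 to compound 4 (0.43 log units; beyond the scatter), resting on a 3.1-fold higher number from compound 2 to compound 1 (0.50 log units; beyond the scatter). Compound 4 is therefore estimated at 400 nM, between 150 nM and 1100 nM.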

Compound 4, half-maximal inhibitory concentration: 13 nM
Compound 4: the middle estimate sits 31-fold (1.49 log units) above what was measured; the whole stated range lies above it.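

In this assay, the swap of 2-fluoro-4-methylphenyl for 2-hydroxyphenyl did not carry from one core to the other: the new step, a 12-fold lower number from compound 3 to compound 4 (1.06 log units; beyond the scatter), runs in the opposite direction to the earlier one, and the gap between them is beyond the scatter: the same change on two cores in this assay, a 3.1-fold higher number (0.50 log units; beyond the scatter) from compound 2 to compound 1 and a 12-fold lower number (1.06 log units; beyond the scatter) from compound 3 to compound 4, 36-fold (1.56 log units) apart, beyond the scatter of two such steps

For these two pairs, then, the size and direction of the step depend on the core that carries it. This does not show what in the two cores produces the difference, and two pairs set no rule for any further core.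

On these data alone, in both pairs the fluorine and the methyl leave together as the hydroxyl enters, and which of these changes matters stays open. As far as these compounds go, whether a 2-methoxyphenyl or a 2-aminophenyl group would split the same way across the two cores also stays open.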